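A few compounds are considered here, and "the series" means these few. Any claim that something is new, unique, unknown or untested is made for them only; others in the source may bear on it.

In an ADME assay, at pH 3 (a lower number here means that the compound disappears faster, a higher number that the compound lasts longer), compound 1 (`COc1cnc(C[S+]([O-])c2nc3cc(OC(F)F)ccc3[nH]2)c(C)c1OC`) gives 0.2 h and compound 2 (`COc1cnc(C[S+]([O-])c2nc3cc(OCC(F)(F)F)ccc3[nH]2)c(C)c1OC`) gives 0.167 h. Compound 3 (`COc1cnc(C[S+]([O-])c2nc3cc(OC(F)(F)C(F)F)ccc3[nH]2)cc1OC`) gives 0.317 h, within the scatter of both. Compound 4 (`COc1cnc(C[S+]([O-])c2nc3cc(OC(F)(F)C(F)F)ccc3[nH]2)c(C)c1OC`) differs from compound 3 by methyl in place of hydrogen on an aromatic carbon. Among the compounds with values here, no measured step isolates this change. The only one, a 1.2-fold lower number from compound 1 to compound 2 (0.08 log units; within the scatter), concerns the group on oxygen instead, and it stays within the scatter. Compound 1 and compound 2 already carry this methyl, and their values stay close to that of compound 3, so no large change is expected in this assay. The expected step is a 1.4-fold lower number from compound 3 to compound 4 (0.14 log units; within the scatter), which would not exceed the scatter. Compound 4 is estimated at 0.23 h, with an expected range of 0.14 h to 0.36 h.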

Compound 4, half-life: 0.333 h
Compound 4: middle estimate off by 1.4-fold (0.16 log units), on the low side; the range from low to high includes it.
By their numbers in this assay, from the lowest: compounds 2, 1, 3 and 4 (each within the scatter of the next).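

In this assay, methyl in place of hydrogen on an aromatic carbon, ortho to a large group, now has a step of its own (a 1.1-fold higher number from compound 3 to compound 4 (0.02 log units; within the scatter)), and at this position the change stays within the scatter. With that methyl present, changing the group on oxygen also stays within the scatter (a 2.0-fold higher number from compound 2 to compound 4 (0.30 log units; within the scatter); a 1.7-fold higher number from compound 1 to compound 4 (0.22 log units; within the scatter)). Nothing available here offers an explanation for these results. As far as these compounds go, it remains open whether an ethyl group or an amine on this aromatic carbon would move the half-life beyond the scatter.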